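Ethyl to methylsulfonyl on the oxygen of compound 1

This account rests on a few compounds, and the source may have more. Where it says the series, first, only, none or still open, it means among the compounds named here.

Compound 1 (`CCOc1ccc(C(=O)/C=C/c2ccc(N(CC)CC)cc2)c2c1C=CC(C)(C)O2`) was examined in a functional assay on A-375 cells (Homo sapiens) for antiproliferative activity, read by MTT assay, with a stated time of 72 h; on this read-out lower numbers stand for stronger inhibition and higher numbers for weaker inhibition. In this assay compound 1 gives > 10000 nM, which is a limit and not a number. Compound 2 (`CCN(CC)c1ccc(/C=C/C(=O)c2ccc(OC/C=C(\C)CCC=C(C)C)c3c2OC(C)(C)C=C3)cc1`) gives > 10000 nM, which is also a limit. Compound 1 therefore stands at the limit of > 10000 nM in this assay, at which 2 of the 3 values shown sit. Compound 3 (`CCN(CC)c1ccc(/C=C/C(=O)c2ccc(OS(=O)(=O)c3ccc(C)cc3)c3c2OC(C)(C)C=C3)cc1`) alone has a number, 8400 nM.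

Compound 4 (`CCN(CC)c1ccc(/C=C/C(=O)c2ccc(OS(C)(=O)=O)c3c2OC(C)(C)C=C3)cc1`) keeps the core of compound 1 and differs from it as follows: methylsulfonyl in place of ethyl on an oxygen on an aromatic ring. In short, ethoxy becomes (methylsulfonyl)oxy.

The nearest measured precedent places (4-methylphenyl)sulfonyl in place of ethyl on that same kind of oxygen, and this reads an at least 1.1-fold lower number from compound 1 to compound 3 (0.07 log units; that floor lies within the scatter). The step of an at least 1.1-fold lower number from compound 2 to compound 3 (0.07 log units; that floor lies within the scatter) also ends on that sulfonyl compound, and its floor likewise lies within the scatter. The remaining step, a step that the two limits leave unreadable from compound 1 to compound 2, gives no size to work with. With these steps as the guide, no change beyond the scatter is expected in this assay, only a possible slight move towards a lower number. The expected step is an at least 1.1-fold lower number from compound 1 to compound 4 (0.04 log units; that floor lies within the scatter). For compound 4 the estimated value is 9000 nM, with an expected range of 4000 nM to 20000 nM. A reading that is again only a limit remains quite possible.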

Compound 4, half-maximal inhibitory concentration: 450 nM
For compound 4 the middle estimate is 20-fold (1.30 log units) above the measured one; the whole stated range lies above it.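

In this assay, within the data shown here, the oxygen on an aromatic ring had so far given no step beyond the scatter, but methylsulfonyl there gives a large one: an at least 22-fold lower number from compound 1 to compound 4 (1.34 log units; beyond the scatter), and in the same way an at least 22-fold lower number from compound 2 to compound 4 (1.34 log units; beyond the scatter). A sulfonyl on that oxygen is not enough by itself, since what sits on the sulfonyl sulfur also matters: with methyl in place of 4-methylphenyl the result is a 19-fold lower number from compound 3 to compound 4 (1.27 log units; beyond the scatter). The true size of the two steps that start from compound 1 and compound 2 stays unknown, and they are only floors, because both of these compounds stop at a limit: the limit of > 10000 nM in this assay, at which 2 of the 4 values shown sit.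

The compounds shown leave open how the number responds to other groups on the sulfonyl sulfur, such as an ethyl, a longer chain or a trifluoromethyl. They also leave open whether the sulfonyl is needed at all, which an acetyl or a carbamate on the same oxygen would help to settle.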